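Sulfonyl substituent swap carried onto a second core

The source may report more compounds than this note shows. Statements on the series, on what has been measured and on what is new or still open speak of the compounds shown alone.

Compound 1 `O=C1[C@@H](NS(=O)(=O)c2ccc(-c3ccon3)s2)CCN1Cc1cc2c[nH]ccc-2n1` and compound 3 `O=C1[C@@H](NS(=O)(=O)c2ccc(-c3ccon3)s2)CCN1Cc1cc2[nH]cccc-2n1` are built from the same atoms joined differently; the difference between the two cores is a group of 9 heavy atoms (7 carbon, 2 nitrogen; one five-membered aromatic ring with 1 hetero atom, one six-membered aromatic ring with 1 hetero atom) in place of a group of 9 heavy atoms (7 carbon, 2 nitrogen; one five-membered aromatic ring with 1 hetero atom, one six-membered aromatic ring with 1 hetero atom), on a saturated chain carbon bound to an amide-type nitrogen in a ring. In an assay on isolated protein for inhibition of coagulation factor X (Oryctolagus cuniculus), tested at 1 uM (on this read-out lower numbers stand for less inhibition and higher numbers for more inhibition at the one concentration tested (going by the name of the read-out)), compound 1 gives 17% and compound 3 gives 31%, which is a step of a number 14 percentage points higher from compound 1 to compound 3 (beyond the scatter).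

Compound 2 `O=C1[C@@H](NS(=O)(=O)c2nc3cc(Cl)ccc3[nH]2)CCN1Cc1cc2c[nH]ccc-2n1` carries the sulfonyl substituent change 5-chloro-1H-benzimidazol-2-yl in place of 5-(1,2-oxazol-3-yl)thiophen-2-yl on a sulfonyl sulfur on the core of compound 1. In this assay compound 2 gives 31%, and the step is a number 14 percentage points higher from compound 1 to compound 2 (beyond the scatter). Compound 2 and compound 3 are level with each other within the scatter, and each stands higher than compound 1.

Compound 4 `O=C1[C@@H](NS(=O)(=O)c2nc3cc(Cl)ccc3[nH]2)CCN1Cc1cc2[nH]cccc-2n1` has not yet been measured. It carries the same sulfonyl substituent change, now on the core of compound 3: 5-chloro-1H-benzimidazol-2-yl in place of 5-(1,2-oxazol-3-yl)thiophen-2-yl on a sulfonyl sulfur. The place is described in the same words for both pairs, so this is the same change made a second time. For the measured compounds named here, only one earlier instance exists, and the two cores have not yet been compared under this change, so the carry-over rests on a single pair.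

For compound 4 the expected step in this assay is a number 11 percentage points higher from compound 3 to compound 4 (beyond the scatter), set a little smaller than the earlier step because compound 3 already gives 31% as a starting point. Compound 4 is estimated at 42% in this assay, with a range from 26% to 58%.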

Compound 4, a percentage reported as inhibition, at one concentration (the size of the read-out at that concentration, not a potency): 14%
For compound 4 the middle estimate is 28 percentage points above the measured one, and the stated range ends above it.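

On the core of compound 3, the change to 5-chloro-1H-benzimidazol-2-yl gives a number 17 percentage points lower from compound 3 to compound 4 (beyond the scatter), so in this assay this sulfonyl substituent change runs in opposite directions on the two cores: the same change on two cores in this assay, a number 14 percentage points higher (beyond the scatter) from compound 1 to compound 2 and a number 17 percentage points lower (beyond the scatter) from compound 3 to compound 4, 31 percentage points apart, beyond the scatter of two such steps. Read the other way, with 5-chloro-1H-benzimidazol-2-yl on the sulfonyl sulfur, the core change gives a number 17 percentage points lower from compound 2 to compound 4 (beyond the scatter), so the core change does not keep its direction across the two sulfonyl substituents either: the same change on two cores in this assay, a number 14 percentage points higher (beyond the scatter) from compound 1 to compound 3 and a number 17 percentage points lower (beyond the scatter) from compound 2 to compound 4, 31 percentage points apart, beyond the scatter of two such steps. The two changes therefore do not add in this set, and the result from one core cannot be carried to the other, but these four compounds do not show why the direction reverses, and they give no rule for any other core or substituent.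

On these data alone, it remains open whether the same reversal appears with other groups on the sulfonyl sulfur, such as a plain phenyl ring or a thiophene bearing a carboxylic acid or an amine. As far as these compounds go, it is also open whether full concentration-response potencies would keep the order seen in these single-concentration percentages.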